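This account rests on a few compounds, and the source may have more. Where it says the series, first, only, none or still open, it means among the compounds named here.

Compound 3 `Cc1nn(-c2ncnc3nc[nH]c23)c2c1C(OCCc1ccccc1)CC(=O)N2` gives 3 nM in a functional assay on HEK293 cells for agonist activity at G-protein coupled receptor 39 (Homo sapiens), read by scintillation proximity assay and inositol phosphate accumulation, with a stated time of 75 min, in the presence of a further agent that is not named here; on this read-out higher numbers stand for an effect only at larger amounts of compound and lower numbers for an effect already at smaller amounts. On that number it stands level with compound 1 `Cc1nn(-c2ncnc3nc[nH]c23)c2c1C(OCC(=O)c1ccc(F)cc1)CC(=O)N2`, which gives 3 nM; together they are the lowest of the three, and the step of no change at the digits printed from compound 1 to compound 3 (within the scatter) lies within the scatter. Compound 2 `Cc1nn(-c2ncnc3nc[nH]c23)c2c1C(c1ccc(OC(C)C)cc1)CC(=O)N2` gives 18 nM in this assay, and the step of a 6.0-fold lower number from compound 2 to compound 3 (0.78 log units; beyond the scatter) is the only one of the two that goes beyond the scatter.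

Compound 4 `Cc1nn(-c2ncnc3nc[nH]c23)c2c1C(C(=O)N(C)c1nccs1)CC(=O)N2` differs from compound 3 in one place: methyl(1,3-thiazol-2-yl)carbamoyl in place of phenethyloxy on a saturated ring carbon. Neither measured step carries a carbamoyl group at this position. The step of a 6.0-fold lower number from compound 2 to compound 3 (0.78 log units; beyond the scatter) shows that exchanging the group on this saturated ring carbon can move the number by a modest amount, while the step of no change at the digits printed from compound 1 to compound 3 (within the scatter) shows that a change further out along the oxygen-linked chain left the number where it was. Compound 4 removes the oxygen-linked chain entirely, so the exchange is of the more far-reaching kind. A step in this assay of about the size seen between compounds 2 and 3, towards a higher number, is therefore expected, though with wide uncertainty. The expected step for compound 4 is a 5.0-fold higher number from compound 3 to compound 4 (0.70 log units; beyond the scatter). Compound 4 is estimated to give 15 nM in this assay, within a range from 3 nM to 80 nM.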

Compound 4, half-maximal effective concentration: 18 nM
For compound 4 the middle estimate is 1.2-fold (0.08 log units) below the measured one; the range from low to high includes it.
By their numbers in this assay, from the lowest: compounds 1 and 3 (each within the scatter of the next); then compounds 2 and 4 (each within the scatter of the next).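

In this assay, replacing phenethyloxy with methyl(1,3-thiazol-2-yl)carbamoyl on this saturated ring carbon gives a 6.0-fold higher number from compound 3 to compound 4 (0.78 log units; beyond the scatter), so an exchange between two groups of equal heavy-atom count still moves the number beyond the scatter. For the compounds shown here, two very different groups bound to this ring carbon through carbon, the carbamoyl and 4-isopropoxyphenyl, give no change at the digits printed from compound 2 to compound 4 (within the scatter), and among the four compounds the two groups bound through oxygen, in compound 1 and compound 3, hold the lowest numbers, with no compound going against this. No supporting data are available to explain this difference.

The compounds shown leave open which part of the methyl(1,3-thiazol-2-yl)carbamoyl group carries the step: the methyl on the amide nitrogen, the 1,3-thiazol-2-yl ring or the carbonyl. Also open, from the compounds shown here alone, is how a primary amine or a carboxylic acid on this saturated ring carbon would read in this assay.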